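Swapping Trifluoromethyl for Phenyl on One Aromatic Carbon

A few compounds are considered here, and "the series" means these few. Any claim that something is new, unique, unknown or untested is made for them only; others in the source may bear on it.

In a functional assay on a cell-free system (Platelet, plasma, Homo sapiens) for inhibition (a lower number here means a stronger inhibitor, a higher number a weaker inhibitor), compound 1 `COc1ccc(C(=O)N(CCN2CCC(OCC(=O)O)CC2)c2ccc(Cl)cc2)cc1` gives 3100 nM. Compound 2 `O=C(O)COC1CCN(CCN(C(=O)c2ccc(C(F)(F)F)cc2)c2ccc(Cl)cc2)CC1` reads > 10000 nM, which is a limit of the assay and not a number. For the measured compounds named here, the only measured step, with trifluoromethyl in place of methoxy, is an at least 3.2-fold higher number from compound 1 to compound 2 (0.50 log units; beyond the scatter). Compound 3 `O=C(O)COC1CCN(CCN(C(=O)c2ccc(-c3ccccc3)cc2)c2ccc(Cl)cc2)CC1` carries phenyl in place of trifluoromethyl on an aromatic carbon. Compound 1, at 3100 nM, shows that a change at this place can bring a measurable value, so a lower number is expected. The expected size is an at least 3.3-fold lower number from compound 2 to compound 3 (0.52 log units; beyond the scatter), though this is only an estimate. For compound 3 the estimated value is 3000 nM, with an expected range of 300 nM to 10000 nM.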

Compound 3, half-maximal inhibitory concentration: > 10000 nM
Compound 3: no number, only a limit (the forecaster's own chance of this, stated with the estimate: 35%); middle value at least 3.3-fold (0.52 log units) away from the limit.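

In this assay, phenyl in place of methoxy gives an at least 3.2-fold higher number from compound 1 to compound 3 (0.50 log units; beyond the scatter). So a second group at this place, this one carrying a ring, also fails to give a measurable value, and methoxy remains the only group here with a number. Compound 2 and compound 3 both stand at a limit of the assay, so the step between them cannot be read: the limit of > 10000 nM in this assay, at which 2 of the 3 values shown sit.

From the compounds shown here alone, whether an amine or a hydroxyl group at this place would give a lower number than compound 1 stays open. Going by these compounds, how compound 2 and compound 3 truly rank also stays open.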